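A few compounds are considered here, and "the series" means these few. Any claim that something is new, unique, unknown or untested is made for them only; others in the source may bear on it.

Compound 1, `N/N=C1\C[C@@H](c2ccc(O)cc2)Oc2cc(O)cc(O)c21`: in a functional assay on L5178Y cells (Mus musculus) for inhibition, read by MTT assay, with a stated time of 24 h (a higher number here means a weaker inhibitor, a lower number a stronger inhibitor), compound 1 gives >= 11300 nM, which is a limit of the assay and not a number.
Compound 2, `COc1cc(O)c2c(c1)O[C@H](c1ccc(O)cc1)C/C2=N\N`: compound 2 gives >= 11300 nM in this assay, again a limit rather than a number.
Compound 3, `COc1ccc([C@@H]2CC(=O)c3c(O)cc(OC)cc3O2)cc1`: compound 3 gives >= 11300 nM in this assay, also a limit.

Compound 3 therefore stands at the limit of >= 11300 nM in this assay, at which 3 of the 3 values shown sit, and no number sets it apart from the other two. Among the compounds with values here, the one measured step between close neighbours, a step that the two limits leave unreadable from compound 1 to compound 2, runs between two limits, so its size cannot be read. The unmeasured compound 4, `CCN(CC)CC(O)COc1ccc([C@@H]2CC(=O)c3c(O)cc(OC)cc3O2)cc1`, differs from compound 3 by 2-(diethylamino)-1-hydroxyethyl in place of hydrogen on a saturated chain carbon bound to an oxygen on an aromatic ring. No measured step involves this change, and the only step shown is unreadable, so nothing here points to a shift in either direction; compound 4 is expected to behave like compound 3 and most likely to reach only the limit again. The step from compound 3 to compound 4 in this assay is expected to be a step that the limit leaves unreadable from compound 3 to compound 4. Compound 4 is accordingly estimated at 15000 nM, with a range from 4000 nM to 60000 nM.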

Compound 4, half-maximal inhibitory concentration: >= 11300 nM
Compound 4: only a limit was reported; the forecaster's own chance of this, stated with the estimate: 70%; the middle value does not contradict the limit.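

Compound 3 and compound 4 both end at a limit of the assay, so no step between them can be read, and the same holds for every other pair: the limit of >= 11300 nM in this assay, at which 4 of the 4 values shown sit.

The compounds shown leave open whether any of them has a readable potency in this assay and whether 3-(diethylamino)-2-hydroxypropoxy in place of methoxy changes it.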